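Anilino for phenoxy on the coumarin-type core

The compounds below may be only part of what the source reports. "The series", "measured", "known", "first", "only" and "open" are said of these compounds alone.

Of the compounds shown here, two have been read in an assay on isolated protein (strain Sprague-Dawley) for inhibition of Amine oxidase [flavin-containing] B (Rattus norvegicus), read by spectrophotometry, with a stated time of 5 min; on this read-out higher numbers stand for weaker inhibition and lower numbers for stronger inhibition. Compound 1 `O=C(COc1cc(=O)oc2cc(OCc3cccc(Cl)c3)ccc12)N1CCCCC1` carries a ((piperidin-1-yl)carbonyl)methyl on an oxygen on an aromatic ring; in this assay compound 1 gives 38900 nM. Compound 2 `O=c1cc(Oc2ccccc2)c2ccc(OCc3cccc(Cl)c3)cc2o1` has a phenyl in that place; in this assay compound 2 gives 4070 nM. The step of a 9.6-fold lower number from compound 1 to compound 2 (0.98 log units; beyond the scatter) is the only one measured so far, and compound 2 therefore stands with the lowest of the two numbers.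

Compound 3 `O=c1cc(Nc2ccccc2)c2ccc(OCc3cccc(Cl)c3)cc2o1` is not yet measured. It differs from compound 2 as follows: anilino in place of phenoxy on an aromatic carbon. Among the measured compounds shown here, no measured step covers an exchange of the oxygen link for a nitrogen link; the step from compound 1 to compound 2 concerns the group on the oxygen, not the linking atom, so it bears on this change only indirectly, in that the phenyl-bearing compound 2 sits at the lower end. With nothing directly comparable, the expectation for compound 3 in this assay is a step of a 1.4-fold lower number from compound 2 to compound 3 (0.13 log units; within the scatter), within the scatter, in either direction. Compound 3 is thus estimated at 3000 nM, with a range from 800 nM to 12000 nM.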

Compound 3, half-maximal inhibitory concentration: 9770 nM
Beside the measured number, compound 3's estimate is 3.3-fold (0.51 log units) below it; the range from low to high includes it.
By their numbers in this assay, from the lowest: compound 2; then compound 3; then compound 1.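

In this assay, the atom linking the phenyl ring to the shared core matters at this position: anilino in place of phenoxy, with the same heavy-atom count and the same carbon-only aromatic ring but one added hydrogen-bond donor, gives a 2.4-fold higher number from compound 2 to compound 3 (0.38 log units; beyond the scatter). The anilino group also compares favourably with the larger group of compound 1, with a 4.0-fold lower number from compound 1 to compound 3 (0.60 log units; beyond the scatter), so at this position both phenyl-bearing links give lower numbers than ((piperidin-1-yl)carbonyl)methoxy, and none of the three compounds goes against this. There is no evidence here on why the nitrogen link gives the higher number of the two phenyl-bearing compounds.

The compounds shown leave open whether the difference between compound 2 and compound 3 follows the nitrogen atom itself or the hydrogen on it, a question that a methylated anilino group or a thioether link to the same phenyl ring could address. Also open, from the compounds shown here alone, is how a benzyl group, with a carbon link, or a phenyl ring bearing a fluorine or methoxy group would read at this position.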